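Phenyl ester variations on a shared chromone core

A few compounds are considered here, and "the series" means these few. Any claim that something is new, unique, unknown or untested is made for them only; others in the source may bear on it.

Compound 1 `COC(=O)c1cc(Cl)ccc1OC(=O)COc1cc(O)c2c(=O)cc(-c3ccccc3)oc2c1`: 3740 nM
Compound 2 `COC(=O)c1c(Cl)cc(Cl)cc1OC(=O)COc1cc(O)c2c(=O)cc(-c3ccccc3)oc2c1`: 43600 nM
Compound 3 `C=C(CCc1cc(O)c2c(=O)cc(-c3ccccc3)oc2c1)Cc1c(Br)cccc1C(=O)CC`: 40700 nM

In a functional assay on cells (T-cell, Mus musculus, strain BALB/c) for inhibition, read by MTT assay, with a stated time of 72 h (a higher number here means a weaker inhibitor, a lower number a stronger inhibitor), compound 1 gives 3740 nM, the lowest number of the three; compound 2 gives 43600 nM and compound 3 gives 40700 nM, both well above it. Compound 4 `COC(=O)c1c(C)cccc1OC(=O)COc1cc(O)c2c(=O)cc(-c3ccccc3)oc2c1` has not been measured in this assay. It differs from compound 1 in one place: a group of 11 heavy atoms (9 carbon, 2 oxygen; one six-membered aromatic ring of carbon only) in place of a group of 11 heavy atoms (8 carbon, 2 oxygen, 1 chlorine; one six-membered aromatic ring of carbon only), on an oxygen next to a carbonyl group. Within the data shown here, no measured pair shows this exact exchange, so the step is expected to be small, either way or none beyond the scatter, with a slight lean toward a weaker inhibitor. For compound 4 the estimate is 5000 nM (1500 nM to 16000 nM), which means an expected step of a 1.3-fold higher number from compound 1 to compound 4 (0.13 log units; within the scatter) in this assay.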

Compound 4, half-maximal inhibitory concentration: 37200 nM
The estimate for compound 4 lay 7.4-fold (0.87 log units) below the measured number; measured number above the stated range.
By their numbers in this assay, from the lowest: compound 1; then compounds 4, 3 and 2 (each within the scatter of the next).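

In this assay, replacing the 4-chloro-2-(methoxycarbonyl)phenyl group, on an oxygen next to a carbonyl group, gives a 9.9-fold higher number from compound 1 to compound 4 (1.00 log units; beyond the scatter), a step beyond the scatter. This position is therefore sensitive to the exchange, even though both groups have the same heavy-atom count, one aromatic ring, and the same hydrogen-bond donor and acceptor counts. No evidence on the cause of the step is available. From the compounds shown here alone, it remains open whether a fluorine, a methoxy group or an amine in place of the chlorine of compound 1 would keep the lower number.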